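The source may report more compounds than this note shows. Statements on the series, on what has been measured and on what is new or still open speak of the compounds shown alone.

Working notes on the amide series sharing the core of compound 1 `COc1ccccc1C(=O)Nc1cccc(-c2oc3cc(-c4ccc(F)cc4)ccc3c(=O)c2O)c1`. Within the data shown here, in a functional assay on GTL 16 cells for antiproliferative activity against GTL 16 cell line (Homo sapiens), read by CCK-8 assay, with a stated time of 72 h (on this read-out lower numbers stand for stronger inhibition and higher numbers for weaker inhibition), compound 1 gives 6370 nM, the lowest of the two numbers measured so far. Compound 2 `O=C(Nc1cccc(-c2oc3cc(-c4ccc(F)cc4)ccc3c(=O)c2O)c1)c1cccc(F)c1` carries a 3-fluorophenyl on the carbonyl carbon in place of the 2-methoxyphenyl; in this assay compound 2 gives 15800 nM, and the step of a 2.5-fold higher number from compound 1 to compound 2 (0.39 log units; beyond the scatter) is the only one measured that bears on a change at this position.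

Compound 3 `O=C(Nc1cccc(-c2oc3cc(-c4ccc(F)cc4)ccc3c(=O)c2O)c1)c1ccc([N+](=O)[O-])cc1` is not yet measured. Its difference from compound 1: 4-nitrophenyl in place of 2-methoxyphenyl on a carbonyl carbon. Among the measured compounds shown here, the one comparable step, a 2.5-fold higher number from compound 1 to compound 2 (0.39 log units; beyond the scatter), shows that exchanging the 2-methoxyphenyl for another aryl on the carbonyl carbon gave a modestly higher number, so a step of similar size and direction is expected here, though the sole precedent leaves the size uncertain. The expected step is a 1.7-fold higher number from compound 1 to compound 3 (0.24 log units; within the scatter). Compound 3 is estimated to give 11000 nM in this assay, within 4000 nM to 30000 nM.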

Compound 3, half-maximal inhibitory concentration: 18200 nM
For compound 3 the middle estimate is 1.7-fold (0.22 log units) below the measured one; low and high end bracket the measured number.
By their numbers in this assay, from the lowest: compound 1; then compounds 2 and 3 (each within the scatter of the next).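

In this assay a second replacement of the 2-methoxyphenyl on the carbonyl carbon moves the same way as the first, with a 2.9-fold higher number from compound 1 to compound 3 (0.46 log units; beyond the scatter) in this comparison, so compound 1 stays lowest against both other aryl groups. The two replacements themselves are not separated, with a 1.2-fold higher number from compound 2 to compound 3 (0.06 log units; within the scatter) leaving the 4-nitrophenyl and the 3-fluorophenyl without an order at this position. Nothing available explains why the 2-methoxyphenyl gives the lower number.

Still open, from the compounds shown here alone, is whether any group on this carbonyl carbon can bring the number clearly under that of compound 1, since all three compounds carry a substituted phenyl there. An unsubstituted phenyl would show what the substituents contribute, while a pyridine, a phenyl bearing a carboxylic acid or an amine, or a butyl chain would test how far the aryl group can be changed.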